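The source may hold more compounds than are shown below. What is called first, only, known or untested is meant among the compounds shown, and "the series" means these compounds.

The measured compounds:
Compound 1 `Cc1cn(C2CCN(Cc3cncc(Oc4cccc(Cl)c4)c3)CC2)c(=O)[nH]c1=O`: in an ADME assay on MRC5 cells (Homo sapiens) for cytotoxicity, read by fluorescence and resazurin assay, with a stated time of 3 days (a lower number here means a stronger inhibitor, a higher number a weaker inhibitor), compound 1 gives > 64000 nM, a limit of the assay and not a number.
Compound 2 `Cc1cn(C2CCN(Cc3cncc(Oc4cc(Cl)cc(Cl)c4)c3)CC2)c(=O)[nH]c1=O`: in this assay compound 2 gives > 64000 nM, likewise a limit and not a number.
Going by the values given here, compound 3 `Cc1cn(C2CCN(Cc3cccc(Oc4ccc(Cl)c(Cl)c4)c3)CC2)c(=O)[nH]c1=O`: in this assay compound 3 gives 6100 nM, the only number among the three.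

Compound 2 and compound 1 differ by hydrogen in place of chloro on an aromatic carbon. The step that the two limits leave unreadable from compound 2 to compound 1 cannot be read in size, since both of its values sit at the limit of > 64000 nM in this assay, at which 2 of the 3 values shown sit. How the core of compound 3 differs from the core of compound 2 is not broken down here.

Compound 4 `Cc1cn(C2CCN(Cc3cccc(Oc4cccc(Cl)c4)c3)CC2)c(=O)[nH]c1=O` has not yet been measured. It differs from compound 3 by hydrogen in place of chloro on an aromatic carbon. This is the same kind of change as that from compound 2 to compound 1, but not the same: in compound 3 the leaving chloro sits ortho to a chloro group and para to a large group, whereas in compound 2 it sits meta to a chloro group and meta to a large group. Among the compounds with values here, the one measured step of this kind gives no usable size, so the expectation rests on compound 3 alone. Resting on compound 3 and its 6100 nM, compound 4 is expected to move by a 2.5-fold higher number from compound 3 to compound 4 (0.39 log units; beyond the scatter), a modest loss allowed by the removal of one chloro. Compound 4 is therefore estimated at 15000 nM, most likely between 5000 nM and 64000 nM.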

Compound 4, half-maximal inhibitory concentration: 21000 nM
Compound 4: middle estimate off by 1.4-fold (0.15 log units), on the low side, and the stated range covers the measured number.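

On the core of compound 3, replacing the chloro of the 3,4-dichlorophenyl group with hydrogen gives a 3.4-fold higher number from compound 3 to compound 4 (0.54 log units; beyond the scatter) in this assay, so this single removal weakens the read-out by more than the usual scatter. The same kind of change on the core of compound 2 cannot be read in size, since both of its values sit at a limit and are not numbers: the limit of > 64000 nM in this assay, at which 2 of the 4 values shown sit. The series therefore offers one readable step and no second size to set against it, and the chloro leaves a different place in each case, so the data neither show that the step carries from one core to the other nor show that it fails to.

The compounds shown leave open how the number moves when the remaining chloro of the 3-chlorophenyl group gives way to hydrogen, fluoro, methoxy or a nitrile. They also leave open how an amine or a carboxylic acid on that ring would read in this assay.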